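Swapping One Halogenated Phenyl for Another on the Nitrogen

The compounds below may be only part of what the source reports. "The series", "measured", "known", "first", "only" and "open" are said of these compounds alone.

Compound 2 `Oc1cc(C(F)(F)F)ccc1-c1nc(-c2ccccc2O)n(-c2ccc(Cl)cc2Cl)n1` is one of two compounds tested in a functional assay on PC-12 cells (Rattus norvegicus) for cytotoxicity, read by MTT assay, with stated times of 2 h and 24 h, tested at 5 uM; a lower number here means a weaker effect, a higher number a stronger effect of the compound at the concentration tested. Compound 1 `Oc1cc(C(F)(F)F)ccc1-c1nc(-c2ccccc2O)n(-c2ccc(I)cc2)n1` gives 94.4% there, and compound 2 gives 86.7%, so compound 2 stands alongside compound 1, the step of a number 7.7 percentage points lower from compound 1 to compound 2 (within the scatter) lying within the scatter. Compound 3 `Oc1cc(C(F)(F)F)ccc1-c1nc(-c2ccccc2O)n(-c2cc(F)cc(F)c2)n1` differs from compound 2 by 3,5-difluorophenyl in place of 2,4-dichlorophenyl on an aromatic nitrogen. Among the measured compounds shown here, the only measured step also exchanged one halogenated phenyl for another on an aromatic nitrogen and produced nothing beyond the scatter, so a step of about a number 1.3 percentage points higher from compound 2 to compound 3 (within the scatter) is expected here, with no clear direction. Compound 3 is therefore estimated at 88%, between 72% and 98%.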

Compound 3, a percentage reported as activity, at one concentration (the size of the read-out at that concentration, not a potency): 100%
Beside the measured number, compound 3's estimate is 12 percentage points below it, outside the stated range (above it).
By their numbers in this assay, from the lowest: compounds 2, 1 and 3 (each within the scatter of the next, the first and the last beyond it).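

Among these halogenated phenyl groups on the aromatic nitrogen, the choice can matter in this assay: a number 13.3 percentage points higher from compound 2 to compound 3 (beyond the scatter) marks the first step here beyond the scatter, though a modest one. By contrast, a number 5.6 percentage points higher from compound 1 to compound 3 (within the scatter) leaves compound 3 and compound 1 indistinguishable. Nothing available explains why the 2,4-dichlorophenyl and 3,5-difluorophenyl groups differ. Still open, as far as these compounds go, is what an unsubstituted phenyl group, or a phenyl carrying an amine or a carboxylic acid, would give on this nitrogen.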